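Aryl swap at the oxadiazole-linked position in a trifluoromethyl ketone series

The source may hold more compounds than are shown below. What is called first, only, known or untested is meant among the compounds shown, and "the series" means these compounds.

Compound 3 `O=C(c1ccc(-c2nc(-c3ccc(Cl)cc3Cl)no2)s1)C(F)(F)F` gives 3000 nM in an assay on isolated protein for inhibition of protein deacetylase HDAC6 (Homo sapiens) (a higher number here means a weaker inhibitor, a lower number a stronger inhibitor), the highest of the three numbers measured. Compound 1 `O=C(c1ccc(-c2nc(-c3ccccn3)no2)s1)C(F)(F)F` gives 500 nM in this assay, and compound 2 `O=C(c1ccc(-c2nc(-c3cccnc3)no2)s1)C(F)(F)F` gives 840 nM; the step of a 1.7-fold higher number from compound 1 to compound 2 (0.23 log units; within the scatter) stays within the scatter. The two steps that reach compound 3, a 6.0-fold higher number from compound 1 to compound 3 (0.78 log units; beyond the scatter) and a 3.6-fold higher number from compound 2 to compound 3 (0.55 log units; beyond the scatter), both lie beyond the scatter and point the same way. Compound 4 `O=C(c1ccc(-c2nc(-c3cccs3)no2)s1)C(F)(F)F` carries the change (thiophen-2-yl in place of 2,4-dichlorophenyl on an aromatic carbon). Among the measured compounds shown here, no measured step involves thiophen-2-yl, so what is known is only that the group at this place has moved the number by modest amounts, and that the two six-membered single-heteroatom rings sit lower than the 2,4-dichlorophenyl. On that basis a modest step downward is expected for a 3.0-fold lower number from compound 3 to compound 4 (0.48 log units; beyond the scatter), landing compound 4 nearer the numbers of compound 1 and compound 2 than that of compound 3. Compound 4 is therefore estimated at 1000 nM in this assay, within a range from 400 nM to 2500 nM.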

Compound 4, half-maximal inhibitory concentration: 670 nM
Compound 4: the middle estimate sits 1.5-fold (0.17 log units) above what was measured; the measured number falls inside the stated range.
By their numbers in this assay, from the lowest: compounds 1, 4 and 2 (each within the scatter of the next); then compound 3.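

In this assay the five-membered thiophen-2-yl cannot be told apart from either pyridine, with a 1.3-fold higher number from compound 1 to compound 4 (0.13 log units; within the scatter) and a 1.3-fold lower number from compound 2 to compound 4 (0.10 log units; within the scatter) both within the scatter. A ring nitrogen is thus not required at this place for a number in this range, and neither is a six-membered ring. With a 4.5-fold lower number from compound 3 to compound 4 (0.65 log units; beyond the scatter) beyond the scatter, compound 3 now stands apart from three otherwise interchangeable aryl groups, and no measurement bearing on the reason for this is available.

From the compounds shown here alone, whether that gap goes with the two chlorine atoms or with the carbon-only six-membered ring remains open, and plain phenyl or 4-chlorophenyl at this place would separate the two. Also open, going by these compounds, is how a ring carrying an amine or a carboxylic acid would read in this assay.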